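Replacing a chlorinated hydrazone with a ketone-derived one

This account rests on a few compounds, and the source may have more. Where it says the series, first, only, none or still open, it means among the compounds named here.

Compound 2 `CC1=CC[C@@H]([C@@](C)(O)CCCC(C)(C)NC(=S)N/N=C\c2ccccc2Cl)CC1` stands at the weak end of the numbers in hand. In a functional assay on NCI/ADR cells (Homo sapiens) for cytotoxicity, read by sulforhodamine B assay (a lower number here means a stronger inhibitor of growth, a higher number a weaker inhibitor of growth), compound 2 gives > 100000 nM, which is a limit of the assay and not a number. Its partner compound 1 `CC1=CC[C@@H]([C@@](C)(O)CCCC(C)(C)NC(=S)N/N=C\c2ccc(C)cc2)CC1` gives 30500 nM in this assay. Within the data shown here, the single measured change, an at least 3.2-fold higher number from compound 1 to compound 2 (0.51 log units; beyond the scatter), is therefore known only as a lower bound, set by the limit of > 100000 nM in this assay, at which 1 of the 2 values shown sits.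

The next compound, compound 3 `CC1=CC[C@@H]([C@@](C)(O)CCCC(C)(C)NC(=S)N/N=C(/C)c2ccccc2)CC1`, differs from compound 2 by a group of 9 heavy atoms (8 carbon, 1 nitrogen; one six-membered aromatic ring of carbon only) in place of a group of 9 heavy atoms (7 carbon, 1 nitrogen, 1 chlorine; one six-membered aromatic ring of carbon only), on an amide-type nitrogen: the chlorine leaves and a group of carbon and nitrogen alone enters. Among the measured compounds shown here, no measured step covers this exact exchange. For the measured compounds named here, the only step that bears on it is the one from compound 1 to compound 2, which shows that the 2-chlorophenyl carried at least a modest loss in this assay; removing it again could recover part of that loss, but the entering group is not the 4-methylphenyl of compound 1, so the size is uncertain. The author expects the step of an at least 2.0-fold lower number from compound 2 to compound 3 (0.30 log units; that floor lies within the scatter) to be a modest fall back toward a measurable number. For compound 3 the estimate in this assay is 50000 nM, with a range from 15000 nM to 100000 nM.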

Compound 3, concentration for total growth inhibition: > 100000 nM
Compound 3 was reported as a limit; the forecaster's own chance of this, stated with the estimate: 40%; middle value at least 2.0-fold (0.30 log units) away from the limit.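

In this assay compound 3 gives > 100000 nM, which is a limit of the assay and not a number. The group entering on the amide-type nitrogen carries no chlorine, yet the readable link to the series is still a loss, an at least 3.2-fold higher number from compound 1 to compound 3 (0.51 log units; beyond the scatter), so among these compounds a chlorine is not required for a fall to the limit. The exchange of the chlorinated group for the chlorine-free one gains nothing that can be seen, and that step itself cannot be read because both of its ends are limits: the limit of > 100000 nM in this assay, at which 2 of the 3 values shown sit.

The compounds shown leave open how far compound 2 and compound 3 each lie past the limit, so no order can be given for them, and compound 1 remains the only one of the three with a readable number. They also leave open whether a 4-chlorophenyl or a 4-methoxyphenyl group on the carbon with a double bond to nitrogen would keep a number that can be read in this assay, or whether that too would reach the limit.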